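A few compounds are considered here, and "the series" means these few. Any claim that something is new, unique, unknown or untested is made for them only; others in the source may bear on it.

Working notes on the series. Compound 1 `c1ccc(Cn2cncc2CNc2cccc(-c3ccccc3)c2)cc1` carries the shared core with an unsubstituted benzyl. In a toxicity assay on NIH3T3 cells (Mus musculus) for cytotoxicity, read by resazurin assay (on this read-out lower numbers stand for an effect already at smaller amounts and higher numbers for an effect only at larger amounts of compound), compound 1 returns > 750 nM, which is a limit of the assay rather than a number, as noted in the limit of > 750 nM in this assay, at which 1 of the 3 values shown sits. Compound 2 `COC(=O)c1ccc(NCc2cncn2Cc2ccc(C#N)cc2)cc1-c1ccccc1` adds the methyl ester and a nitrile on the benzyl ring. In this assay compound 2 returns > 10000 nM, again a limit and not a number, as noted in the limit of > 10000 nM in this assay, at which 1 of the 3 values shown sits. Compound 3 `COC(=O)c1ccc(NCc2cncn2Cc2ccc(OC)cc2)cc1-c1ccccc1` is the 4-methoxybenzyl analogue; for compound 3 in this assay the record shows "not determined" (no result reported), so compound 3 stands on no number at all.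

Compound 4 `COC(=O)c1ccc(NCc2cncn2Cc2cccc(C(C)(C)C)c2)cc1-c1ccccc1` differs from compound 3 by 3-(tert-butyl)phenyl in place of 4-methoxyphenyl on a saturated chain carbon bound to an aromatic nitrogen. Among the measured compounds shown here, no measured pair in the set differs in only one place, so no step size is available; in this assay no step beyond the scatter is expected from this change, with a further limit the most likely outcome. For compound 4 in this assay the estimate is 10000 nM, within 3000 nM to 30000 nM.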

Compound 4, half-maximal effective concentration: > 1000 nM
Compound 4 was reported as a limit (the forecaster's own chance of this, stated with the estimate: 75%); the middle value lies beyond the limit too.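

In this assay compound 4 gives > 1000 nM, which is a limit and not a number. Among the compounds shown here, compound 2 also stands on a limit, so no step between compound 2 and compound 4 can be read. The compounds shown leave open whether the benzyl substituent shifts the value at all.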